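This account rests on a few compounds, and the source may have more. Where it says the series, first, only, none or still open, it means among the compounds named here.

Measured so far:
- compound 1 `CCc1ccccc1NC(=O)N[C@@H](C)c1ccccc1` — 100%
- compound 2 `CC(=O)c1ccccc1NC(=O)N[C@H](C)c1ccccc1` — 96%
- compound 3 `CC(=O)c1ccccc1NC(=O)N[C@@H](C)c1ccccc1` — 100%

In an ADME assay on the whole organism with Oryza sativa as the target, tested at 0.1 uM (on this read-out higher numbers stand for a weaker effect at the one concentration tested and lower numbers for a stronger effect), compound 3 gives 100%, level with compound 1 at the digits shown; together they hold the highest of the three numbers, and compound 2 lies furthest away. Both measured steps stayed within the scatter: no change at the digits printed from compound 1 to compound 3 (within the scatter) and a number 4 percentage points higher from compound 2 to compound 3 (within the scatter), the latter resting on (the fact that compounds 2 and 3 differ only in the configuration as drawn). Compound 4 `C[C@H](NC(=O)Nc1ccccc1I)c1ccccc1` differs from compound 3 in one place: iodo in place of acetyl on an aromatic carbon. Going by the values given here, no measured step puts an iodo group in this place, and the one step that swapped a group on this aromatic carbon moved nothing beyond the scatter. A step no larger than the scatter is therefore expected, a number 2 percentage points lower from compound 3 to compound 4 (within the scatter). Compound 4 is estimated at 98%, with a range from 88% to 100%.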

Compound 4, a percentage reported as activity, at one concentration (the size of the read-out at that concentration, not a potency): 99%
Estimate against measurement, compound 4: 1 percentage points below; the range from low to high includes it.
By their numbers in this assay, from the lowest: compounds 2, 4, 1 and 3 (each within the scatter of the next).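

On this aromatic carbon, iodo, a single heavy atom, takes the place of acetyl and of ethyl, and in this assay both swaps stay small, with a number 1 percentage points lower from compound 3 to compound 4 (within the scatter) and a number 1 percentage points lower from compound 1 to compound 4 (within the scatter) on record. Across these compounds, then, three different groups at this place give no step beyond the scatter. Nothing on hand offers a reason for this.

On these data alone, whether an amine, a carboxylic acid or a longer chain on this carbon would give a larger step stays open. So does whether the configuration as drawn matters with iodo in place.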